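This account rests on a few compounds, and the source may have more. Where it says the series, first, only, none or still open, it means among the compounds named here.

Measured in a physicochemical assay for lipophilicity, using the shake flask method, measured as octanol-water partition, at pH 7.4; a higher number here means a more lipophilic compound, a lower number a more polar compound:
- compound 1 `CC(C)Cn1cc(-c2ccnc3[nH]c(C4CCN(CC(=O)N(C)C)CC4)cc23)ccc1=O`: 2
- compound 2 `CN(C)C(=O)CN1CCC(c2cc3c(-c4ccc(=O)n(CC5CCOCC5)c4)ccnc3[nH]2)CC1`: 1.4
- compound 3 `CN(C)C(=O)CN1CCC(c2cc3c(-c4ccc(=O)n(C5CCC5)c4)ccnc3[nH]2)CC1`: 1.9

Compound 3 and compound 1 cannot be told apart on these numbers, with a step of a number 0.10 log units lower from compound 1 to compound 3 (within the scatter). Compound 2 stands apart, with a step of a number 0.50 log units higher from compound 2 to compound 3 (beyond the scatter).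

The next compound, not yet measured, is compound 4 `CN(C)C(=O)CN1CCC(c2cc3c(-c4ccc(=O)n(C)c4)ccnc3[nH]2)CC1`. The change is methyl in place of cyclobutyl on an aromatic nitrogen.

Within the data shown here, all three measured steps touch the group on this nitrogen, but none reaches a group as small as methyl, so the data give no direct precedent. The step between the two groups made of carbon alone, a number 0.10 log units lower from compound 1 to compound 3 (within the scatter), shows little. Among the measured compounds shown here, the only steps beyond the scatter, a number 0.60 log units lower from compound 1 to compound 2 (beyond the scatter) and a number 0.50 log units higher from compound 2 to compound 3 (beyond the scatter), are modest and involve the oxan-4-yl group.

Losing carbon atoms points to a downward move of similar or slightly larger size. The expected step is a number 0.70 log units lower from compound 3 to compound 4 (beyond the scatter). The estimate for compound 4 is 1.2, with an expected range of 0.8 to 1.6.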

Compound 4, distribution coefficient: 1.1
For compound 4 the middle estimate is 0.10 log units above the measured one; measured number inside the range.
By their numbers in this assay, from the lowest: compounds 4 and 2 (each within the scatter of the next); then compounds 3 and 1 (each within the scatter of the next).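

In this assay, the group on the aromatic nitrogen now gives steps beyond the scatter between groups made of carbon alone, a number 0.80 log units lower from compound 3 to compound 4 (beyond the scatter) and a number 0.90 log units lower from compound 1 to compound 4 (beyond the scatter), whereas the exchange of isobutyl for cyclobutyl stayed within it. Methyl and (oxan-4-yl)methyl cannot be told apart, with a number 0.30 log units lower from compound 2 to compound 4 (within the scatter). The number at this position therefore does not follow the count of heavy atoms alone, and compound 2 goes against such a trend.

Open, going by these compounds, is where an amine or a carboxylic acid carried on a chain at this nitrogen would fall relative to these groups. Also open, on these data alone, is whether a straight propyl chain would fall with methyl or with isobutyl.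

Nothing shown here gives a reason for these steps.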